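The compounds below may be only part of what the source reports. "The series", "measured", "known", "first", "only" and "open" are said of these compounds alone.

Of the compounds shown here, three built on one shared core have so far been measured in a functional assay on HT-1080 cells (Homo sapiens) for cytotoxicity, read by MTT assay, with a stated time of 72 h (on this read-out higher numbers stand for weaker inhibition and lower numbers for stronger inhibition), and they sit close together. Compound 1 `COc1ccc(/C=C2\CCC/C(=C\c3cccc(Br)c3)C2=O)cc1OC` gives 5200 nM in this test, compound 2 `COc1cccc(/C=C2\CCC/C(=C\c3ccc(OC)c(OC)c3)C2=O)c1` gives 4600 nM under the same conditions, and compound 3 `COc1ccc(/C=C2\CCC/C(=C\c3cccc(Cl)c3Cl)C2=O)cc1OC` gives 8800 nM as its reading. Compound 3 thus stands level with the other two. The data show a 1.7-fold higher number from compound 1 to compound 3 (0.23 log units; within the scatter) and a 1.9-fold higher number from compound 2 to compound 3 (0.28 log units; within the scatter) while the remaining pair shows a 1.1-fold lower number from compound 1 to compound 2 (0.05 log units; within the scatter) and none of these separates any two of the three.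

The next case is compound 4 `COc1ccc(/C=C2\CCC/C(=C\c3ccc(Cl)c(Cl)c3)C2=O)cc1OC` which differs from compound 3 in one group only: 3,4-dichlorophenyl in place of 2,3-dichlorophenyl on a double-bonded chain carbon bound to a double-bonded ring carbon that is, 3,4-dichlorophenyl in place of 2,3-dichlorophenyl on a double-bonded chain carbon bound to a double-bonded ring carbon. For the measured compounds named here, no measured step isolates a change of this kind. The closest evidence is the two steps into compound 3 named above, which replace the whole substituted phenyl at this same place and stayed within the scatter. The estimated step is a 1.5-fold lower number from compound 3 to compound 4 (0.17 log units; within the scatter) and no change beyond the scatter is expected in this assay in either direction. For compound 4 the estimated value is 6000 nM with an expected range from 2800 nM to 13000 nM in this measurement.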

Compound 4, half-maximal inhibitory concentration: 3100 nM
Estimate against measurement, compound 4: 1.9-fold (0.29 log units) above; low and high end bracket the measured number.
By their numbers in this assay, from the lowest: compounds 4, 2, 1 and 3 (each within the scatter of the next, the first and the last beyond it).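

In this assay, for the compounds shown here, the change of 3,4-dichlorophenyl in place of 2,3-dichlorophenyl on a double-bonded chain carbon bound to a double-bonded ring carbon gives a 2.8-fold lower number from compound 3 to compound 4 (0.45 log units; beyond the scatter), the first step to pass beyond the scatter. Going by these compounds alone, the two groups have the same atoms and the same counts, so this place responds, if only modestly, to how the two chlorines are arranged on the phenyl, which the earlier steps, all within the scatter, could not show. Compound 4 is separated from compound 3 alone, since a 1.5-fold lower number from compound 2 to compound 4 (0.17 log units; within the scatter) and a 1.7-fold lower number from compound 1 to compound 4 (0.22 log units; within the scatter) both stay within the scatter, and nothing measured here bears on why the two dichlorophenyl groups differ.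

The compounds shown leave open whether the same rearrangement of the two chlorines would give a step of this size with other groups elsewhere on the shared core. They also leave open how this place would respond to a phenyl carrying an amine or a carboxylic acid, or to a longer chain in place of the phenyl.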